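Swapping a bulky amide substituent for a plain phenyl

The source may hold more compounds than are shown below. What is called first, only, known or untested is meant among the compounds shown, and "the series" means these compounds.

Two amides built on the same core have been tested in a functional assay on MGC-803 cells (Homo sapiens) for antiproliferative activity, read by MTT assay, with a stated time of 72 h; a higher number here means a weaker inhibitor, a lower number a stronger inhibitor. Compound 1 `CCCSc1nc(Cl)c2c(n1)N(Cc1ccccc1)C(C(=O)N1CCN(Cc3ccccc3)CC1)N2` gives 51200 nM. Compound 2 `CCCSc1nc(Cl)c2c(n1)N(Cc1ccccc1)C(C(=O)NCCC1=CCc3ccccc31)N2` gives 27000 nM, the lower of the two numbers, though compound 1 sits within the scatter of it, so neither can be called the stronger. Compound 3 `CCCSc1nc(Cl)c2c(n1)N(Cc1ccccc1)C(C(=O)Nc1ccccc1)N2` carries a group of 6 heavy atoms (6 carbon; one six-membered aromatic ring of carbon only) in place of a group of 11 heavy atoms (11 carbon; one five-membered non-aromatic ring of carbon only, one six-membered aromatic ring of carbon only), on an amide-type nitrogen. For the measured compounds named here, with no measured step of this kind to lean on, the change is expected to move the number little, if at all, beyond the scatter. Compound 3 is therefore estimated at 30000 nM, within 10000 nM to 90000 nM, a step of a 1.1-fold higher number from compound 2 to compound 3 (0.05 log units; within the scatter).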

Compound 3, half-maximal inhibitory concentration: 58400 nM
Estimate against measurement, compound 3: 1.9-fold (0.29 log units) below; low and high end bracket the measured number.
By their numbers in this assay, from the lowest: compounds 2, 1 and 3 (each within the scatter of the next, the first and the last beyond it).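

Putting phenyl on the amide-type nitrogen in place of the larger two-ring group gives a 2.2-fold higher number from compound 2 to compound 3 (0.34 log units; beyond the scatter) in this assay and so weakens the compound modestly. For the compounds shown here, this is the first single change at this position with a measured size, and it shows that the group on this nitrogen can shift the number, if only slightly. Still open, on these data alone, is whether an amine or a carboxylic acid on the phenyl ring would move the number further in either direction. Nothing measured here accounts for the step.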